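Hydrazone aryl swaps on a shared core: cytotoxicity notes

The compounds below may be only part of what the source reports. "The series", "measured", "known", "first", "only" and "open" are said of these compounds alone.

Measured so far, in a functional assay on HT-29 cells (Homo sapiens) for cytotoxicity, read by MTT assay, with a stated time of 72 h; on this read-out higher numbers stand for weaker inhibition and lower numbers for stronger inhibition:
- compound 1 `CN(C)CCn1cnnc1-c1cc(Oc2ccc(NC(=O)N/N=C/c3c[nH]c4ccccc34)cc2F)ccn1` gives 1300 nM
- compound 2 `CN(C)CCn1cnnc1-c1cc(Oc2ccc(NC(=O)N/N=C/c3ccc(O)c(Br)c3)cc2F)ccn1` gives 450 nM
- compound 3 `CN(C)CCn1cnnc1-c1cc(Oc2ccc(NC(=O)N/N=C/c3c(O)ccc4ccccc34)cc2F)ccn1` gives 670 nM

All three share one core and differ only in the aryl group on the carbon with a double bond to nitrogen. Compound 3 sits second highest of the three numbers in this assay; its nearest neighbour is compound 2, the step of a 1.5-fold higher number from compound 2 to compound 3 (0.17 log units; within the scatter), and its furthest is compound 1, the step of a 1.9-fold lower number from compound 1 to compound 3 (0.29 log units; within the scatter), so compound 3 cannot be separated from either. For the measured compounds named here, the only step beyond the scatter in the set is a 2.9-fold lower number from compound 1 to compound 2 (0.46 log units; beyond the scatter).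

Compound 4 `CN(C)CCn1cnnc1-c1cc(Oc2ccc(NC(=O)N/N=C/c3cccc(Br)c3)cc2F)ccn1` is the next member. It differs from compound 3 as follows: 3-bromophenyl in place of 2-hydroxynaphthalen-1-yl on a carbon with a double bond to nitrogen. The three measured steps all concern the same position and all fall in a narrow band, with two of them within the scatter. Going by the values given here, nothing measured so far speaks to removing both the hydroxyl and the second ring at once. Given that band, the step of a 1.2-fold higher number from compound 3 to compound 4 (0.08 log units; within the scatter) is expected to stay small, most likely within the scatter, with no clear direction. In this assay compound 4 is therefore estimated at 800 nM, with a range from 300 nM to 2500 nM.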

Compound 4, half-maximal inhibitory concentration: 380 nM
Beside the measured number, compound 4's estimate is 2.1-fold (0.32 log units) above it; the range from low to high includes it.
By their numbers in this assay, from the lowest: compounds 4, 2, 3 and 1 (each within the scatter of the next, the first and the last beyond it).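

For the compounds shown here, the step of a 1.2-fold lower number from compound 2 to compound 4 (0.07 log units; within the scatter) is the first direct read on the hydroxy group of the 3-bromo-4-hydroxyphenyl ring: it lies within the scatter, so in this assay that hydroxy group is not required for a number in this range. The step of a 1.8-fold lower number from compound 3 to compound 4 (0.25 log units; within the scatter) also lies within the scatter, which shows that 3-bromophenyl, with no hydrogen-bond donor and a single aromatic ring, cannot be separated from 2-hydroxynaphthalen-1-yl on the carbon with a double bond to nitrogen. The step of a 3.4-fold lower number from compound 1 to compound 4 (0.53 log units; beyond the scatter) lies beyond the scatter and, together with the earlier step from compound 1 to compound 2, sets 1H-indol-3-yl apart from both bromine-bearing aryl groups, although compound 3 still cannot be separated from compound 1.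

No measurement shown accounts for any of these steps. Still open, from the compounds shown here alone, is the role of the bromine itself: a plain phenyl, or a phenyl carrying an amine or a carboxylic acid in place of the bromine, would show whether this aryl position tolerates such groups in this assay.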